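The source may report more compounds than this note shows. Statements on the series, on what has been measured and on what is new or still open speak of the compounds shown alone.

Compound 1 `O=[N+]([O-])c1ccc(S(=O)(=O)n2c(-c3cn(-c4ccccc4)nc3-c3ccc(F)cc3)nc3ccccc32)cc1`: > 300000 nM (a limit of the assay)
Compound 2 `O=S(=O)(c1ccc(Cl)cc1)n1c(-c2cn(-c3ccccc3)nc2-c2ccc(F)cc2)nc2ccccc21`: 231000 nM

Both results come from an ADME assay on cells (Hepatocyte, Mus musculus) for cytotoxicity, read by MTT assay, with a stated time of 24 h; a higher number here means that more compound is tolerated, a lower number that less compound is tolerated. For the measured compounds named here, compound 2 holds the only true number so far, 231000 nM. Compound 1 gives only a limit, > 300000 nM. With so little data, compound 2 cannot be ranked in any wider series.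

Compound 3 `O=S(=O)(c1ccc(C(F)(F)F)cc1)n1c(-c2cn(-c3ccccc3)nc2-c2ccc(F)cc2)nc2ccccc21` keeps the core of compound 2 and differs by trifluoromethyl in place of chloro on an aromatic carbon. In words, trifluoromethyl stands in place of chloro on an aromatic carbon, para to a large group.

Going by the values given here, one measured step bears on this, and it also exchanges a group on an aromatic carbon: an at least 1.2-fold lower number from compound 1 to compound 2 (0.11 log units; that floor lies within the scatter). That step is a floor and not a full size, so it is only a weak guide. Among the compounds with values here, it offers no sign of a large shift, and no measured step involves trifluoromethyl. In this assay, no change beyond the scatter is therefore expected. The expected step is a 1.1-fold lower number from compound 2 to compound 3 (0.02 log units; within the scatter). Compound 3 is estimated at 220000 nM, with an expected range from 110000 nM to 300000 nM.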

Compound 3, half-maximal cytotoxic concentration: 55300 nM
Beside the measured number, compound 3's estimate is 4.0-fold (0.60 log units) above it; measured number below the stated range.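

In this assay, for the compounds shown here, this position, para to a large group, turns out not to be indifferent to the group it carries: the only earlier step here stayed within the scatter, whereas trifluoromethyl in place of chloro gives a 4.2-fold lower number from compound 2 to compound 3 (0.62 log units; beyond the scatter). Trifluoromethyl in place of nitro gives an at least 5.4-fold lower number from compound 1 to compound 3 (0.73 log units; beyond the scatter), so compound 3 is the least tolerated of the three compounds, and exchanging one group on this aromatic carbon is enough to produce a shift beyond the scatter. The step that starts from compound 1 is a floor and not a full size, as compound 1 gives only a limit of the assay: the limit of > 300000 nM in this assay, at which 1 of the 3 values shown sits.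

With only three groups at one position, nothing shown explains why trifluoromethyl gives a lower number than chloro, or whether the shift is specific to this group. As far as these compounds go, it also remains open how an amine, a carboxylic acid or a simple methyl group would read at this place, and whether the same exchange on a different core would give a step of similar size.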